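The source may report more compounds than this note shows. Statements on the series, on what has been measured and on what is new or still open speak of the compounds shown alone.

Measured compounds:
Compound 1, `C#Cc1nc2ccccc2[se]1`, gives 25000 nM in a functional assay on HCT-116 cells (Homo sapiens) for cytotoxicity, with a stated time of 3 days; a higher number here means a weaker inhibitor, a lower number a stronger inhibitor.
Compound 2, `Brc1nc2ccccc2[se]1`, gives only > 40000 nM in this assay, which is a limit of the assay and not a number.
Compound 3, `C#CCNC(=O)c1csc(C#C)n1`, gives 19200 nM in this assay.

Compound 4, `C#CCNC(=O)c1csc(Br)n1`, is not yet measured. The change from compound 3 to compound 4 is bromo in place of ethynyl on an aromatic carbon. The same kind of change is seen from compound 1 to compound 2, (bromo in place of ethynyl on an aromatic carbon); the surroundings differ, since in compound 1 the ring holds selenium and is part of a fused or bridged system of two rings, whereas in compound 3 the ring holds sulfur and the place is two ring bonds from the ring atom that bears a group of 6 heavy atoms. How the core of compound 3 differs from the core of compound 1 is not broken down here. The measured step gave an at least 1.6-fold higher number from compound 1 to compound 2 (0.20 log units; that floor lies within the scatter), its size bounded by the limit of > 40000 nM in this assay, at which 1 of the 3 values shown sits. Compound 3 and compound 1 lie within the scatter of each other. Compound 4 is expected to give 40000 nM. That expectation means a step of a 2.1-fold higher number from compound 3 to compound 4 (0.32 log units; beyond the scatter), resting on the direction of the earlier at least 1.6-fold higher number from compound 1 to compound 2 (0.20 log units; that floor lies within the scatter).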

Compound 4, half-maximal inhibitory concentration: > 40000 nM
Compound 4: no number, only a limit; the forecaster's own chance of this, stated with the estimate: 55%; the middle value sits exactly at the limit.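

In this assay, putting bromo in place of ethynyl on an aromatic carbon brings an at least 2.0-fold higher number from compound 3 to compound 4 (0.31 log units; beyond the scatter), and the change points the same way on both cores shown: the same change on two cores in this assay, an at least 1.6-fold higher number (0.20 log units; that floor lies within the scatter) from compound 1 to compound 2 and an at least 2.0-fold higher number (0.31 log units; beyond the scatter) from compound 3 to compound 4; the limit leaves it open whether they differ. The direction therefore carries from the core of compound 1 to the core of compound 3, but the size of the step cannot be compared, since the bromo compounds on both cores stop at the assay's limit: the limit of > 40000 nM in this assay, at which 2 of the 4 values shown sit. Two cores show only that the direction held in these two cases, not that it holds across the series.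

Open, from the compounds shown here alone, is whether other groups at this place, such as a nitrile or an amine, would keep any of the activity of ethynyl. Also open, going by these compounds, is how the result would change with a carboxylic acid in place of the group of 6 heavy atoms.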